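Removing a double bond from compound 2

A few compounds are considered here, and "the series" means these few. Any claim that something is new, unique, unknown or untested is made for them only; others in the source may bear on it.

In a functional assay on MCF7 cells (Homo sapiens) for antiproliferative activity, read by MTT assay, with a stated time of 48 h (a lower number here means a stronger inhibitor, a higher number a weaker inhibitor), compound 1 `COc1cc(CNC(=O)CCCCCCC(C)C)ccc1OCCCCOc1ccc(C(N)=S)cc1` gives 4990 nM and compound 2 `COc1cc(CNC(=O)CCCC/C=C/C(C)C)ccc1OCCCCCOc1ccc(C(N)=S)cc1` gives 17200 nM, so compound 2 holds the higher of the two exact numbers and is the weaker inhibitor of this pair. Compound 3 `COc1cc(CNC(=O)CCCC/C=C/C(C)C)ccc1OCCCCCOc1ccc(-c2cc(=S)ss2)cc1` gives > 50000 nM, which is a limit of the assay and not a number.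

Compound 4 `COc1cc(CNC(=O)CCCCCCC(C)C)ccc1OCCCCCOc1ccc(C(N)=S)cc1` has not yet been measured. It differs from compound 2 by isopentyl in place of 3-methylbut-1-en-1-yl on a saturated chain carbon, four bonds along the chain from a carbonyl carbon: isopentyl in place of 3-methylbut-1-en-1-yl, on a saturated chain carbon, four bonds along the chain from a carbonyl carbon. The double bond in that group is therefore lost.

Among the compounds with values here, the one measured step, an at least 2.9-fold higher number from compound 2 to compound 3 (0.46 log units; beyond the scatter), lies beyond the scatter, but it exchanges a different group and sets no size for this change. Within the data shown here, no measured step makes this exchange alone. Among the measured compounds shown here, the only hint is that compound 1 gives 4990 nM, a lower number than that of compound 2. No step beyond the scatter is therefore expected, only a slight lean towards a lower number, estimated as a 1.6-fold lower number from compound 2 to compound 4 (0.19 log units; within the scatter). For compound 4 the expected value in this assay is 11000 nM, with an estimated range from 4500 nM to 26000 nM.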

Compound 4, half-maximal inhibitory concentration: 49300 nM
For compound 4 the middle estimate is 4.5-fold (0.65 log units) below the measured one; measured number above the stated range.
By their numbers in this assay, from the lowest: compound 1; then compound 2; then compound 4. At a limit, above all of these: compound 3.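

In this assay, the double bond turns out to matter at this place, on a saturated chain carbon, four bonds along the chain from a carbonyl carbon: isopentyl in place of 3-methylbut-1-en-1-yl gives a 2.9-fold higher number from compound 2 to compound 4 (0.46 log units; beyond the scatter), so compound 4 is the weaker inhibitor of this pair. The stronger result of compound 1 cannot be credited to the isopentyl end alone, since compound 1 and compound 4 share that end and the larger group of compound 4 at the other place gives a 9.9-fold higher number from compound 1 to compound 4 (0.99 log units; beyond the scatter). Compound 3 gives a limit and not a number, so its exact rank against compound 4 stays unknown: the limit of > 50000 nM in this assay, at which 1 of the 4 values shown sits.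

The compounds shown do not tell why losing the double bond weakens compound 4, nor whether the same change would act in the same direction on the smaller group of compound 1. They also leave open what a longer chain, or an amine or a carboxylic acid, would do in place of the isopentyl end.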